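Swapping an ester for a methyl on the phenyl ring

The source may hold more compounds than are shown below. What is called first, only, known or untested is meant among the compounds shown, and "the series" means these compounds.

Of the compounds shown here, two with a shared core have been tested in a functional assay on IMR-32 cells for inhibition of Voltage-dependent N-type calcium channel subunit alpha-1B (Homo sapiens), read by calcium flux; on this read-out higher numbers stand for weaker inhibition and lower numbers for stronger inhibition. Compound 1 `CC1=NC(C)=C(C(=O)O)C(c2ccccc2)/C1=C(\O)OC/C=C/c1ccccc1` gives 2000 nM. Compound 2 `COC(=O)c1cccc(C2C(C(=O)O)=C(C)N=C(C)/C2=C(/O)OC/C=C/c2ccccc2)c1` gives 4600 nM, the higher of the two numbers, meaning it is the weaker inhibitor, with compound 1 the nearest comparison. Among the measured compounds shown here, the one measured step, a 2.3-fold higher number from compound 1 to compound 2 (0.36 log units; beyond the scatter), is modest but beyond the scatter.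

Compound 3 `CC1=NC(C)=C(C(=O)O)C(c2cccc(C)c2)/C1=C(\O)OC/C=C/c1ccccc1` is the next case. Its change from compound 2 is methyl in place of methoxycarbonyl on an aromatic carbon, a methyl in place of methoxycarbonyl, on an aromatic carbon of a six-membered aromatic ring of carbon only, meta to a large group. For the measured compounds named here, no measured step covers this exact swap; only the hydrogen-to-methoxycarbonyl step from compound 1 to compound 2 is related, and methyl sits between those two groups. A small step in this assay, back toward the number of compound 1, is therefore expected, a 1.6-fold lower number from compound 2 to compound 3 (0.22 log units; within the scatter). Compound 3 is estimated at 2800 nM, with a range from 1200 nM to 6500 nM.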

Compound 3, half-maximal inhibitory concentration: 1800 nM
Estimate against measurement, compound 3: 1.6-fold (0.19 log units) above; measured number inside the range.
By their numbers in this assay, from the lowest: compounds 3 and 1 (each within the scatter of the next); then compound 2.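

In this assay, the 3-(methoxycarbonyl)phenyl to 3-methylphenyl change gives a 2.6-fold lower number from compound 2 to compound 3 (0.41 log units; beyond the scatter), so the group on this aromatic carbon can shift the number in either direction. Methyl in place of hydrogen on the same carbon gives a 1.1-fold lower number from compound 1 to compound 3 (0.05 log units; within the scatter), so among these three compounds this position accepts a methyl without a change that stands out from the scatter, and only methoxycarbonyl goes with a higher number. Nothing measured here explains why methoxycarbonyl and methyl read differently.

These three compounds leave open how an amine, a nitrile or a longer carbon chain on this aromatic carbon would read. They also leave open whether methyl and methoxycarbonyl would keep the same order on another carbon of that ring.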